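Replacing 1H-pyrazol-1-yl with 2-hydroxyphenyl in compound 3

A few compounds are considered here, and "the series" means these few. Any claim that something is new, unique, unknown or untested is made for them only; others in the source may bear on it.

- compound 1 `NC1CCC(Nc2nc(NCc3ccc(-c4cccc(F)c4)cc3)c3ncn(C4CCCC4)c3n2)CC1` gives 445 nM
- compound 2 `NC1CCC(Nc2nc(NCc3ccc(-n4cccn4)cc3)c3ncn(C4CCCC4)c3n2)CC1` gives 170 nM

Among the compounds with values here, in a functional assay on HeLa cells (Homo sapiens) for inhibition, with a stated time of 72 h (a higher number here means a weaker inhibitor, a lower number a stronger inhibitor), compound 2 at 170 nM holds the lower of the two numbers so far, with compound 1 at 445 nM as its only neighbour. Compound 3 `NC1CCC(Nc2nc(NCc3ccc(-c4ccccc4O)cc3)c3ncn(C4CCCC4)c3n2)CC1` keeps the shared core and differs from compound 2 in one group (2-hydroxyphenyl in place of 1H-pyrazol-1-yl on an aromatic carbon) on the aromatic carbon that also changes between the two measured compounds. Within the data shown here, one measured step bears on this, a 2.6-fold lower number from compound 1 to compound 2 (0.42 log units; beyond the scatter) and it came with 1H-pyrazol-1-yl in place of 3-fluorophenyl. Compound 3 again carries a six-membered aromatic ring of carbon only at that place, as compound 1 does at 445 nM so a modest move towards higher numbers in this assay is expected, of about that size or less. Among the measured compounds shown here, no measured compound carries a 2-hydroxyphenyl group, which leaves the estimate wide. The estimated step is a 1.9-fold higher number from compound 2 to compound 3 (0.27 log units; within the scatter) and remains uncertain. For compound 3 the estimate is 320 nM with an expected span of 120 nM to 850 nM for four of five measurements.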

Compound 3, half-maximal inhibitory concentration: 4180 nM
The estimate for compound 3 lay 13-fold (1.12 log units) below the measured number; measured number outside the range, above it.
By their numbers in this assay, from the lowest: compound 2; then compound 1; then compound 3.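

In this assay, the aromatic carbon para to a large group proves far more sensitive to the choice of group than the first pair suggested: a 25-fold higher number from compound 2 to compound 3 (1.39 log units; beyond the scatter), with 2-hydroxyphenyl in place of 1H-pyrazol-1-yl. The two groups built on a six-membered aromatic ring of carbon only also sit well apart, a 9.4-fold higher number from compound 1 to compound 3 (0.97 log units; beyond the scatter), with 2-hydroxyphenyl in place of 3-fluorophenyl, so the ring type alone does not set the number at this position and what the ring carries matters as well. Nothing at hand accounts for the size of these steps.

From the compounds shown here alone, it remains open whether the rise follows the hydroxyl group itself or its place on the ring, a question that plain phenyl, 3-hydroxyphenyl and 2-methoxyphenyl at this carbon would separate. Also open, going by these compounds, is whether 2-aminophenyl follows 2-hydroxyphenyl, and whether another five-membered aromatic ring, such as imidazol-1-yl, stays near compound 2 at 170 nM.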